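Cyclic Hydroxyalkyl Amine Replaces an Open Carboxylic Acid

The source may report more compounds than this note shows. Statements on the series, on what has been measured and on what is new or still open speak of the compounds shown alone.

Measured so far in an assay on HEK293 cells for displacement of a labelled ligand from melanin-concentrating hormone receptor 1 (Homo sapiens); a higher number here means a weaker inhibitor, a lower number a stronger inhibitor:
- Compound 1 `O=C(NC[C@H]1CCCC[C@H]1O)NC1CCN(Cc2ccn(-c3ccc(C(F)(F)F)cc3)c2)CC1` gives 63 nM in this assay.
- Compound 2 `O=C(NC1CCN(Cc2ccn(-c3ccc(C(F)(F)F)cc3)c2)CC1)N1CCCC(CO)C1` gives 23 nM in this assay.
- Compound 3 `O=C(O)CC(NC(=O)NC1CCN(Cc2ccn(-c3ccc(C(F)(F)F)cc3)c2)CC1)c1ccccc1` gives 412 nM in this assay.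

Compound 3 has the highest number of the three and is therefore the weakest inhibitor among them: compound 1 stands nearest, with a 6.5-fold higher number from compound 1 to compound 3 (0.82 log units; beyond the scatter), and compound 2 stands furthest, with an 18-fold higher number from compound 2 to compound 3 (1.25 log units; beyond the scatter). Compound 4 `O=C(NC1CCN(Cc2ccn(-c3ccc(C(F)(F)F)cc3)c2)CC1)N1CCCCC1CCO` has not yet been measured. It differs from compound 3 in one place: 2-(2-hydroxyethyl)piperidin-1-yl in place of (2-carboxy-1-phenylethyl)amino on a carbonyl carbon. This moves the group on the carbonyl carbon back toward the kind found in compound 2, where a 3-(hydroxymethyl)piperidin-1-yl group occupies that position and the lowest number of the set was reached. The step from compound 2 to compound 3 was large and the step from compound 1 to compound 3 modest; both argue that undoing the acid in favour of a ring carrying a hydroxyalkyl chain should lower the number substantially. A large fall is therefore expected, a 14-fold lower number from compound 3 to compound 4 (1.14 log units; beyond the scatter), bringing compound 4 close to compound 2. Compound 4 is estimated at 30 nM, with a range from 10 nM to 100 nM.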

Compound 4, half-maximal inhibitory concentration: 39 nM
The estimate for compound 4 lay 1.3-fold (0.11 log units) below the measured number; the measured number falls inside the stated range.
By their numbers in this assay, from the lowest: compounds 2, 4 and 1 (each within the scatter of the next, the first and the last beyond it); then compound 3.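

In this assay the swap to 2-(2-hydroxyethyl)piperidin-1-yl on this carbonyl carbon gives an 11-fold lower number from compound 3 to compound 4 (1.02 log units; beyond the scatter), so the recovery from compound 3 does not depend on the exact 3-(hydroxymethyl)piperidin-1-yl group. The two piperidine groups cannot be told apart, with a 1.7-fold higher number from compound 2 to compound 4 (0.23 log units; within the scatter), and the ring-bound nitrogen of compound 4 cannot be told apart from the open amide-type nitrogen of compound 1, with a 1.6-fold lower number from compound 1 to compound 4 (0.21 log units; within the scatter). Only compound 3, which carries a carboxylic acid and a phenyl ring, stands apart from the other three, and that single compound cannot show which of the two matters.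

No measurement shown here accounts for these differences. Open too, as far as these compounds go, is whether a plain 2-ethylpiperidin-1-yl group would keep the number of compound 4, and whether a 2-(carboxymethyl)piperidin-1-yl group would raise it toward that of compound 3.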